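The compounds below may be only part of what the source reports. "The series", "measured", "known", "first", "only" and "open" are said of these compounds alone.

In an ADME assay on microsomes from liver (Mus musculus) for metabolic stability, read by LC-MS, with a stated time of 10 min, tested at 0.5 uM (on this read-out lower numbers stand for a less stable compound and higher numbers for a more stable compound), compound 1 `c1ccc2c(c1)CN[C@@H](CN(CC[C@H]1CCCNC1)[C@H]1CCCc3cccnc31)C2` gives 56%, which places it second highest among the three measured compounds. Compound 2 `c1cnc2c(c1)CCC[C@@H]2N(CCCN1CCNCC1)Cc1nc2ccccc2[nH]1` gives 68%, a gap above compound 1 that lies beyond the usual scatter. Compound 3 `CN1CCN(CCCN(C[C@H]2Cc3ccccc3CN2C)[C@H]2CCCc3cccnc32)CC1` gives 43%, a gap below compound 1 that also lies beyond the scatter. Compound 4 `c1ccc2c(c1)CN[C@@H](CN(CCCN1CCN(C3CC3)CC1)[C@H]1CCCc3cccnc31)C2` has not yet been measured. It differs from compound 1 in one place: (4-cyclopropylpiperazin-1-yl)methyl in place of piperidin-3-yl on a saturated chain carbon, two bonds along the chain from an amine nitrogen. Within the data shown here, no pair of measured compounds differs in only one place, so no measured step guides this change. Compound 4 is expected to show a modest downward step a number 8 percentage points lower from compound 1 to compound 4 (within the scatter) in this assay, probably not far beyond the scatter. The estimate for compound 4 is 48%, within a range from 28% to 68%.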

Compound 4, percent of the compound remaining: 3%
For compound 4 the middle estimate is 45 percentage points above the measured one, outside the stated range (below it).
By their numbers in this assay, from the lowest: compound 4; then compound 3; then compound 1; then compound 2.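

In this assay, replacing piperidin-3-yl with (4-cyclopropylpiperazin-1-yl)methyl gives a large fall (a number 53 percentage points lower from compound 1 to compound 4 (beyond the scatter)), so the read-out is sensitive to the group at this place on the chain. Among these compounds, this is the first one-place comparison in the set, and it puts compound 4 lowest of the four. Nothing at hand explains the fall. The compounds shown do not tell whether it goes with the cyclopropyl or with the piperazine ring. A morpholine ring in place of the piperazine could help separate the two.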